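Removing One Methoxy Group from a Strong Cytotoxic Hydrazone

A few compounds are considered here, and "the series" means these few. Any claim that something is new, unique, unknown or untested is made for them only; others in the source may bear on it.

Measured so far in a functional assay on cells (Mus musculus) for cytotoxicity, read by MTT assay, with a stated time of 24 h, tested at 1 uM; a higher number here means a stronger effect of the compound at the concentration tested, a lower number a weaker effect:
compound 1 `COc1cc(/C=N/Nc2nc3ccccc3s2)cc(OC)c1O` gives 39%
compound 2 `COc1cc(/C=N/N(C)c2nc3ccccc3s2)cc(OC)c1O` gives 107%
compound 3 `COc1cc(/C=N/N(C)c2nc3ccccc3s2)cc(OC)c1OC` gives 7%

Compound 2 stands highest of the three numbers, with a number 68 percentage points higher from compound 1 to compound 2 (beyond the scatter) and a number 100 percentage points lower from compound 2 to compound 3 (beyond the scatter) both beyond the scatter. Compound 4 `COc1cc(/C=N/N(C)c2nc3ccccc3s2)ccc1O` differs from compound 2 by hydrogen in place of methoxy on an aromatic carbon. Among the compounds with values here, no measured step removes a methoxy group, so neither step bears directly on this change. The step to compound 3 shows that altering the hydroxy group costs much activity, but compound 4 keeps that group intact. A modest loss is therefore expected, a number 27 percentage points lower from compound 2 to compound 4 (beyond the scatter), with wide uncertainty. Compound 4 is estimated at 80%, in a range from 35% to 115%.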

Compound 4, a percentage reported as activity, at one concentration (the size of the read-out at that concentration, not a potency): 96%
Compound 4: middle estimate off by 16 percentage points, on the low side; the range from low to high includes it.
By their numbers in this assay, from the lowest: compound 3; then compound 1; then compound 4; then compound 2.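

In this assay, replacing one methoxy group with hydrogen costs little, a number 11 percentage points lower from compound 2 to compound 4 (beyond the scatter), a modest step even though it lies beyond the scatter. Most of the effect therefore survives the loss of this methoxy group, ortho to a hydroxy group, whereas putting methyl on the hydroxy oxygen gave a number 100 percentage points lower from compound 2 to compound 3 (beyond the scatter). No measurement on hand explains why this change is so small. Still open, going by these compounds, is how an ethoxy group, a fluorine or an amine would behave at this place, and whether the remaining methoxy group matters.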